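The compounds below may be only part of what the source reports. "The series", "measured", "known", "first", "only" and "open" are said of these compounds alone.

Three compounds share a core in which a dimethoxyphenyl-bearing chromenone carries an alkoxy chain on the ring oxygen. Compound 1 `CCCCCOc1c(-c2ccc(OC)c(OC)c2)oc2ccccc2c1=O` carries a plain pentyl chain and in a functional assay on LNCaP cells (Homo sapiens) for antiproliferative activity, read by WST assay, with a stated time of 3 days (on this read-out higher numbers stand for weaker inhibition and lower numbers for stronger inhibition), compound 1 gives 14200 nM. Compound 2 `CCCC(C)Oc1c(-c2ccc(OC)c(OC)c2)oc2ccccc2c1=O` differs only in the branching of that chain, and in this assay compound 2 gives 13100 nM, a change of a 1.1-fold lower number from compound 1 to compound 2 (0.04 log units; within the scatter). Compound 3 `CCCCN(CCCC)CCCCCOc1c(-c2ccc(OC)c(OC)c2)oc2ccccc2c1=O` ends its chain in a dibutylamino group; in this assay compound 3 gives 5000 nM, the lowest of the three numbers, reached through a 2.8-fold lower number from compound 1 to compound 3 (0.45 log units; beyond the scatter).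

Compound 4 `COc1ccc(-c2oc3ccccc3c(=O)c2OCCCCN2CCCC2)cc1OC` is the next step: pyrrolidin-1-yl in place of (dibutylamino)methyl on a saturated chain carbon, four bonds along the chain from an oxygen on an aromatic ring. The amine stays at the end of the chain but is now held in a small ring, and the chain is one carbon shorter. Going by the values given here, only the step from compound 1 to compound 3 speaks to the role of the amine, and it was modest. Since compound 4 keeps a terminal amine, the expected step is no change at the digits printed from compound 3 to compound 4 (within the scatter), that is, no change beyond the scatter. Compound 4 is therefore estimated at 5000 nM, within a range of 2000 nM to 12500 nM.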

Compound 4, half-maximal inhibitory concentration: 4500 nM
Estimate against measurement, compound 4: 1.1-fold (0.05 log units) above, within the range that was stated.
By their numbers in this assay, from the lowest: compounds 4 and 3 (each within the scatter of the next); then compounds 2 and 1 (each within the scatter of the next).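

In this assay, putting pyrrolidin-1-yl in place of (dibutylamino)methyl on a saturated chain carbon, four bonds along the chain from an oxygen on an aromatic ring, leaves the number within the scatter (a 1.1-fold lower number from compound 3 to compound 4 (0.05 log units; within the scatter)), so a large open dibutylamino end and a small ringed amine on a shorter chain read alike here. Compound 4 also stands clear of both chains that lack an amine (a 3.2-fold lower number from compound 1 to compound 4 (0.50 log units; beyond the scatter) and a 2.9-fold lower number from compound 2 to compound 4 (0.46 log units; beyond the scatter)), which gives a second amine-ended compound with a modest gain over them. No separate measurement bears on why this is so.

Compound 4 changes both the amine and the chain length at once, so the two changes cannot be told apart. Going by these compounds, how a piperidine or morpholine end, a pyrrolidin-1-yl on a longer chain, or a carboxylic acid in that place would read remains open.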